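The source may report more compounds than this note shows. Statements on the series, on what has been measured and on what is new or still open speak of the compounds shown alone.

Measured so far:
- compound 1, `Cc1cccc(NC(=O)CN2CCC(c3ccc(Cl)cc3)CC2)c1`: 70200 nM in a functional assay on cells for antagonist activity at D(4) dopamine receptor (Homo sapiens), read by TR-FRET and cAMP accumulation, with a stated time of 30 min; on this read-out lower numbers stand for stronger inhibition and higher numbers for weaker inhibition
- compound 2, `Cc1cccc(NC(=O)CCN2CCN(c3ncccn3)CC2)c1`: 2120 nM

Compound 1 stands at the highest of the two numbers in this assay, and the gap to compound 2 is far beyond the scatter of repeated measurements, so compound 1 is the weaker of the two by a wide margin. The compound to be examined next is compound 3, `Cc1ccc(C2CCN(CC(=O)Nc3cccc(C)c3)CC2)cc1`. It differs from compound 1 in a single place: methyl in place of chloro on an aromatic carbon. The exchange happens on the six-membered aromatic ring of carbon only, and neither group entering nor leaving brings a ring, a hydrogen-bond donor, a hydrogen-bond acceptor or a charge. Going by the values given here, no measured pair in this set shows what such a swap does, so the expectation rests on the small size of the change alone. An exchange of one heavy atom for another on the same aromatic carbon is expected to move the number little, if at all, so the step of a 1.1-fold higher number from compound 1 to compound 3 (0.06 log units; within the scatter) is expected to stay within the usual scatter. Compound 3 is therefore estimated at 80000 nM, with a plausible range from 30000 nM to 250000 nM.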

Compound 3, half-maximal inhibitory concentration: 3060 nM
Compound 3: middle estimate off by 26-fold (1.42 log units), on the high side, outside the stated range (below it).
By their numbers in this assay, from the lowest: compounds 2 and 3 (each within the scatter of the next); then compound 1.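

In this assay, methyl in place of chloro gives a 23-fold lower number from compound 1 to compound 3 (1.36 log units; beyond the scatter), so this aromatic carbon is far from indifferent to what it carries, even though the exchange involves only one heavy atom. The computed counts are the same on both sides of the exchange: neither group has a ring, a hydrogen-bond donor, a hydrogen-bond acceptor or a net charge, so these counts do not separate 4-chlorophenyl from 4-methylphenyl, and a large step can arise without any change in them. No measurement is available here that would explain the step, so the data show its size but not its cause.

Going by these compounds alone, what a fluoro group, a methoxy group, an amine or a plain hydrogen would do on this same carbon remains open, so two groups give only a single comparison and no trend across substituents. This one pair also leaves open whether methyl in place of chloro would give a step of similar size on a different core.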